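The source may hold more compounds than are shown below. What is called first, only, known or untested is meant among the compounds shown, and "the series" means these compounds.

Compound 3 `COc1cc[nH]c1/C=C1\C(=O)Nc2ccc(F)c(C#C[C@H](CO)NCCO)c21` stands weakest of the three measured compounds in a functional assay on MDA-MB-435 cells (Homo sapiens) for inhibition; on this read-out higher numbers stand for weaker inhibition and lower numbers for stronger inhibition: compound 3 gives 1270 nM, while compound 1 `COc1cc[nH]c1/C=C1\C(=O)Nc2ccc(F)c(C#C[C@@H](C)O)c21` gives 110 nM and compound 2 `COc1cc[nH]c1/C=C1\C(=O)Nc2ccc(F)c(C#C[C@@H](N)CO)c21` gives 300 nM. Compound 4 `COc1cc[nH]c1/C=C1\C(=O)Nc2ccc(F)c(C#C[C@@H]3C[C@@H](O)CN3)c21` differs from compound 3 by 4-hydroxypyrrolidin-2-yl in place of 2-hydroxy-1-((2-hydroxyethyl)amino)ethyl on a triple-bonded carbon. Among the compounds with values here, two measured steps bear on it: the step of a 4.2-fold higher number from compound 2 to compound 3 (0.63 log units; beyond the scatter) and the step of a 12-fold higher number from compound 1 to compound 3 (1.06 log units; beyond the scatter), both showing that the open chain with its added hydroxyethyl group costs activity. Folding that chain into a ring removes part of what compound 3 carries, so a modest step back toward the number of compound 2 is expected, though the ring itself has no measured precedent here. On this basis compound 4 is expected to give 500 nM, between 150 nM and 1600 nM, which would mean an expected 2.5-fold lower number from compound 3 to compound 4 (0.40 log units; beyond the scatter).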

Compound 4, half-maximal inhibitory concentration: 63 nM
The estimate for compound 4 lay 7.9-fold (0.90 log units) above the measured number; the whole stated range lies above it.
By their numbers in this assay, from the lowest: compounds 4 and 1 (each within the scatter of the next); then compound 2; then compound 3.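

In this assay, the 4-hydroxypyrrolidin-2-yl group on the triple-bonded carbon gives a 20-fold lower number from compound 3 to compound 4 (1.30 log units; beyond the scatter) and a 4.8-fold lower number from compound 2 to compound 4 (0.68 log units; beyond the scatter), so at this position a nitrogen held in a ring reads far better than the open-chain amines did. Against the 1-hydroxyethyl group, the change gives a 1.7-fold lower number from compound 1 to compound 4 (0.24 log units; within the scatter), so carrying an amine nitrogen here need not weaken inhibition. Nothing available here gives a reason for these steps. The compounds shown do not separate the ring from its hydroxyl group. Going by these compounds, how a pyrrolidin-2-yl group without that hydroxyl, or a piperidin-2-yl ring, would read stays open.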